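Solubility notes on the shared-core series, step to compound 4

This account rests on a few compounds, and the source may have more. Where it says the series, first, only, none or still open, it means among the compounds named here.

Measured so far:
compound 1, `C[C@]1(COc2ccc(NC(=O)Nc3ccc(C(F)(F)F)cc3)cc2)Cn2cc([N+](=O)[O-])nc2O1`, gives < 1 ug/mL, a limit of the assay.
compound 2, `COc1ccc(S(=O)(=O)N2CCN(c3ccc(OC[C@@]4(C)Cn5cc([N+](=O)[O-])nc5O4)cc3)CC2)cc1`, gives < 1 ug/mL, a limit of the assay.
compound 3, `C[C@]1(COc2ccc(NC(=S)Nc3ccc(OC(F)(F)F)cc3)cc2)Cn2cc([N+](=O)[O-])nc2O1`, gives < 1 ug/mL, a limit of the assay.

In a physicochemical assay for solubility, read by HPLC, with a stated time of 4 h, at pH 7 (a lower number here means a less soluble compound, a higher number a more soluble compound), compound 1 returns < 1 ug/mL, which is a limit and not a number. In this assay compound 2 likewise returns < 1 ug/mL, again only a limit. Compound 3 gives < 1 ug/mL in this assay, a limit as well. Compound 2 therefore stands nowhere distinct within the values shown: it sits at the same floor as the other two, which is all that is known, as the limit of < 1 ug/mL in this assay, at which 3 of the 3 values shown sit, records. Among the measured compounds shown here, no pair of measured compounds differs in one place, so no measured step exists for comparison.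

The unmeasured compound 4, `C[C@]1(COc2ccc(N3CCN(S(=O)(=O)c4ccc(F)cc4)CC3)cc2)Cn2cc([N+](=O)[O-])nc2O1`, differs from compound 2 as follows: fluoro in place of methoxy on an aromatic carbon. Because the limit of < 1 ug/mL in this assay, at which 3 of the 3 values shown sit, holds for every value shown, the step from compound 2 to compound 4 is expected to be no larger than the scatter, with compound 4 expected to remain at the floor. Compound 4 is accordingly estimated at 0.5 ug/mL, in the range 0.1 ug/mL to 2 ug/mL. That estimate means an expected step that the limit leaves unreadable from compound 2 to compound 4.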

Compound 4, solubility: 8.33 ug/mL
Compound 4: the middle estimate sits 17-fold (1.22 log units) below what was measured, outside the stated range (above it).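

In this assay, fluoro in place of methoxy on an aromatic carbon, para to a large group, comes with an at least 8.3-fold higher number from compound 2 to compound 4 (0.92 log units; beyond the scatter). This shows that the series can leave the floor of the assay, and that a single change at this position of the (4-methoxyphenyl)sulfonyl group is enough for that to be seen, with compound 4 as the only compound shown that gives a readable number. The true size of the step stays unknown, since compound 2 holds only a limit in this assay, and the same limit gives no ordering among the other compounds: the limit of < 1 ug/mL in this assay, at which 3 of the 4 values shown sit.

The compounds shown leave open whether the higher number belongs to fluoro specifically, as they offer no second group at this position for comparison, such as a chloro, a nitrile, an amine or a carboxylic acid. Among the compounds shown here, they also leave open whether the same change would lift compound 1 or compound 3 off the limit, as both differ from compound 4 in more than one place and no step to either can be read.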